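The source may report more compounds than this note shows. Statements on the series, on what has been measured and on what is new or still open speak of the compounds shown alone.

Compound 1 `Cc1noc(-c2nc(C)c3c(c2N)C(=O)N(Cc2ccc(F)cc2)C3=O)n1` and compound 2 `Cc1noc(-c2nc(C)c3c(c2N)C(=O)N(Cc2ccc(Cl)cc2)C3=O)n1` share one core and have both been tested in a physicochemical assay for solubility, using the shake flask method, in simulated intestinal fluid, measured as kinetic solubility, with a stated time of 2 h, at 25 degrees C, at pH 6.5; a lower number here means a less soluble compound, a higher number a more soluble compound. Compound 1 gives < 5000 nM, which is a limit of the assay and not a number. Compound 2 gives < 5000 nM, which is also only a limit, so it has no exact standing. The evidence so far amounts to the limit of < 5000 nM in this assay, at which 2 of the 2 values shown sit. Going by the values given here, the only measured step is a step that the two limits leave unreadable from compound 1 to compound 2, so it offers no size to carry forward.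

Compound 3 `Cc1noc(-c2nc(C)c3c(c2N)C(=O)N(Cc2ccc(OC(F)(F)F)cc2)C3=O)n1` has trifluoromethoxy in place of the chloro of compound 2, on an aromatic carbon: trifluoromethoxy in place of chloro on an aromatic carbon. With no readable step to go on, no change beyond the scatter is expected, in either direction. The expected step in this assay is a step that the limit leaves unreadable from compound 2 to compound 3. This expectation rests on compound 2, whose < 5000 nM is a limit. Another limit is the likeliest report. For compound 3 the estimate is 2500 nM, with an expected range from 800 nM to 6000 nM.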

Compound 3, solubility: < 5000 nM
Compound 3: a limit, no number (the forecaster's own chance of this, stated with the estimate: 85%); the middle value is on the limit's open side.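

In this assay, going by these compounds alone, compound 3 gives < 5000 nM, which is a limit and not a number, so no step from compound 1 or compound 2 to compound 3 can be read. The compounds shown leave open whether these three differ at all, and what they offer stops at one point: the limit of < 5000 nM in this assay, at which 3 of the 3 values shown sit.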